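The compounds below may be only part of what the source reports. "The series", "measured", "known", "first", "only" and "open" are said of these compounds alone.

The study measures two compounds in a functional assay on HeLa cells (Homo sapiens) for antiproliferative activity, read by CCK-8 assay, with a stated time of 72 h, tested at 2 uM; on this read-out higher numbers stand for a stronger effect at the one concentration tested and lower numbers for a weaker effect. Compound 1 `CC1CCCCN1C(=S)SCc1ccc(C(=O)Nc2ccccc2N)cc1` gives 45.5% in this assay, and compound 2 `Nc1ccccc1NC(=O)c1ccc(CSC(=S)N2CCc3ccc([N+](=O)[O-])cc32)cc1` gives 45.7%. Going by the values given here, compound 1 thus stands at one of only two numbers available, and its gap to compound 2 lies within the scatter, so the two are not set apart from each other by this read-out. Among the compounds with values here, no pair of measured compounds differs in a single place, so no measured step exists to calibrate a change.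

Compound 3 `CC1CCN(C(=S)SCc2ccc(C(=O)Nc3ccccc3N)cc2)CC1` has not been measured. It differs from compound 1 by 4-methylpiperidin-1-yl in place of 2-methylpiperidin-1-yl on a thiocarbonyl carbon. Within the data shown here, with the same atoms joined differently and no measured step to rest on, the step expected in this assay is none beyond the scatter, in either direction. Compound 3 is therefore expected to give about 45%, estimated between 28% and 62%. The step this estimate implies, a number 0.5 percentage points lower from compound 1 to compound 3 (within the scatter), is expected to be negligible.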

Compound 3, a percentage reported as inhibition, at one concentration (the size of the read-out at that concentration, not a potency): 46.8%
Beside the measured number, compound 3's estimate is 1.8 percentage points below it; the measured number falls inside the stated range.
By their numbers in this assay, from the lowest: compounds 1, 2 and 3 (each within the scatter of the next).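

In this assay, going by these compounds alone, the first measured step at this position, 4-methylpiperidin-1-yl in place of 2-methylpiperidin-1-yl on a thiocarbonyl carbon, is a number 1.3 percentage points higher from compound 1 to compound 3 (within the scatter). Within the data shown here, for this one pair, moving the methyl group around the piperidine ring is therefore not told apart by the read-out, something the earlier compounds could not show, since no two of them differed in a single place. Nothing available bears on why the two compounds read alike.

From the compounds shown here alone, whether a morpholine, a piperazine or a 4-phenylpiperidine on the same thiocarbonyl carbon would give a step beyond the scatter in this assay remains open. Going by these compounds, each number also comes from a single concentration, so how compound 1 and compound 3 compare in potency remains open as well.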